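The source may hold more compounds than are shown below. What is called first, only, known or untested is meant among the compounds shown, and "the series" means these compounds.

Compound 1 `CC(C)C(C)(C)/N=C(\NC#N)Nc1cccnc1`, compound 2 `CCC(C)(CC)/N=C(\NC#N)Nc1cccnc1` and compound 3 `CC(C)C(C)(C)/N=C(\NC#N)Nc1ccncc1` were tested in a functional assay on the whole organism (blood, strain Wistar-Okamoto) with Rattus norvegicus as the target, with a stated time of 5 days; on this read-out higher numbers stand for an effect only at larger amounts of compound and lower numbers for an effect already at smaller amounts. Compound 1 gives 1 mg/kg, compound 2 gives 0.5 mg/kg, and compound 3 gives 20 mg/kg. The change from compound 1 to compound 2 is 1-ethyl-1-methylpropyl in place of 1,1,2-trimethylpropyl on a double-bonded nitrogen, and it made a 2.0-fold lower number from compound 1 to compound 2 (0.30 log units; within the scatter). The cores of compound 1 and compound 3 differ by pyridin-4-yl in place of pyridin-3-yl on an amine nitrogen, which made a 20-fold higher number from compound 1 to compound 3 (1.30 log units; beyond the scatter). Compound 4 `CCC(C)(CC)/N=C(\NC#N)Nc1ccncc1` is not yet measured; it carries the same change as compound 2, namely (1-ethyl-1-methylpropyl in place of 1,1,2-trimethylpropyl on a double-bonded nitrogen), at the same place. Because the same change gave a 2.0-fold lower number from compound 1 to compound 2 (0.30 log units; within the scatter), the step from compound 3 to compound 4 is expected to be a 1.7-fold lower number from compound 3 to compound 4 (0.22 log units; within the scatter). Compound 4 is therefore estimated at 12 mg/kg, in a range from 5 mg/kg to 30 mg/kg.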

Compound 4, minimum effective dose: 0.5 mg/kg
For compound 4 the middle estimate is 24-fold (1.38 log units) above the measured one, and the stated range ends above it.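

In this assay, the change to 1-ethyl-1-methylpropyl gave a 40-fold lower number from compound 3 to compound 4 (1.60 log units; beyond the scatter), so the size of its effect did not carry over from the core of compound 1 to the core of compound 3: the same change on two cores in this assay, a 2.0-fold lower number (0.30 log units; within the scatter) from compound 1 to compound 2 and a 40-fold lower number (1.60 log units; beyond the scatter) from compound 3 to compound 4, 20-fold (1.30 log units) apart, beyond the scatter of two such steps. Pyridin-4-yl in place of pyridin-3-yl gave a large step with 1,1,2-trimethylpropyl but no change at the digits printed from compound 2 to compound 4 (within the scatter), so the two changes do not simply add up: the same change on two cores in this assay, a 20-fold higher number (1.30 log units; beyond the scatter) from compound 1 to compound 3 and no change at the digits printed (within the scatter) from compound 2 to compound 4, 20-fold (1.30 log units) apart, beyond the scatter of two such steps. A step measured on one core was therefore a poor guide to the same step on the other, but these two pairs do not show why, or whether this holds for other groups.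

The compounds shown leave open how a tert-butyl or cyclohexyl group on the double-bonded nitrogen would behave with either pyridinyl group. They also leave open what pyridin-2-yl on the amine nitrogen would do.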